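The source may hold more compounds than are shown below. What is called first, only, known or untested is meant among the compounds shown, and "the series" means these compounds.

In a physicochemical assay for pharmacokinetics, read by HPLC, in phosphate buffer, at pH 7.4 (on this read-out lower numbers stand for a shorter-lived compound and higher numbers for a longer-lived compound), compound 1 (`CCCC(CCC)C(=O)N(C)/N=N/c1ccc(C(=O)OC)cc1`) gives 31.4 h, and compound 2 (`CCCC(CCC)C(=O)N(C)/N=N/c1ccc(Cl)cc1`) gives 27.3 h. Compound 3 (`CCCC(=O)N(C)/N=N/c1ccc(C#N)cc1`) reads > 40 h, which is a limit and not a number. Compound 4 (`CC(C)C(=O)N(C)/N=N/c1ccc(C#N)cc1`) has not yet been measured and is reached from compound 3 by isopropyl in place of propyl on a carbonyl carbon, with isopropyl in place of propyl on a carbonyl carbon. Among the measured compounds shown here, the only measured step, a 1.2-fold lower number from compound 1 to compound 2 (0.06 log units; within the scatter), has chloro in place of methoxycarbonyl on an aromatic carbon, a different place. For the measured compounds named here, no measured step changes the group on the carbonyl carbon, so it offers no size or direction for this change. In this assay, the expected step, a step that the limit leaves unreadable from compound 3 to compound 4, is therefore not expected to exceed the scatter. For compound 4 the estimated half-life is 50 h, with an expected range of 28 h to 90 h.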

Compound 4, half-life: > 40 h
Compound 4 was reported as a limit (the forecaster's own chance of this, stated with the estimate: 65%); the middle value lies beyond the limit too.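

Among the compounds shown here, compound 3 and compound 4 both read as limits, not numbers, so no step between them can be read in this assay: the limit of > 40 h in this assay, at which 2 of the 4 values shown sit. The compounds shown leave open whether isopropyl in place of propyl on a carbonyl carbon changes the half-life at all.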